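Dropping the methyl from an amino-sugar pyrimidine nucleoside

The source may report more compounds than this note shows. Statements on the series, on what has been measured and on what is new or still open speak of the compounds shown alone.

Compound 1 `NC1CC(n2cc(F)c(=O)[nH]c2=O)OC1CO` gives 15 uM in a functional assay on L1210 cells (Mus musculus) for cytotoxicity; on this read-out lower numbers stand for an effect already at smaller amounts and higher numbers for an effect only at larger amounts of compound. Compound 2 `Cc1cn([C@H]2C[C@H](N)[C@@H](CO)O2)c(=O)[nH]c1=O` gives 0.8 uM.

Of the two measured compounds, compound 2 carries the lowest number, and compound 1 lies above it by a gap beyond the usual scatter. Compound 3 `N[C@H]1C[C@H](n2ccc(=O)[nH]c2=O)O[C@@H]1CO` differs from compound 2 at a single spot: hydrogen in place of methyl on an aromatic carbon. No measured pair differs in exactly one place, so the weight of this change is not shown directly. An upward step of modest size is expected in this assay, namely a 5.0-fold higher number from compound 2 to compound 3 (0.70 log units; beyond the scatter). Compound 3 is therefore estimated at 4 uM, most likely between 1 uM and 20 uM.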

Compound 3, concentration for half-maximal effect: 18 uM
Compound 3: the middle estimate sits 4.5-fold (0.65 log units) below what was measured; the range from low to high includes it.
By their numbers in this assay, from the lowest: compound 2; then compounds 1 and 3 (each within the scatter of the next).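

Replacing the methyl with hydrogen on this aromatic carbon gives a 23-fold higher number from compound 2 to compound 3 (1.35 log units; beyond the scatter) in this assay. Among these compounds, this is the first direct reading of this position, and it shows that the methyl alone, with nothing else in the structure altered, weighs heavily in this cytotoxicity read-out. No measurement at hand explains why this change has so large an effect. Still open, on these data alone, is how an ethyl group, a longer chain or a chlorine atom on this same carbon would compare with the methyl of compound 2.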